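The source may hold more compounds than are shown below. What is called first, only, known or untested is meant among the compounds shown, and "the series" means these compounds.

The measured compounds, with their results in an assay on T-REx-293 cells for inhibition of potassium channel subfamily T member 1 (Homo sapiens), read by patch clamp; on this read-out higher numbers stand for weaker inhibition and lower numbers for stronger inhibition:
Compound 1 `C[C@H](NC(=O)c1cc(C(F)(F)F)nn1C)c1nc(-c2cccc(F)c2)no1` gives 136 nM.
Compound 2 `Cc1cccc(-c2noc([C@H](C)NC(=O)c3cc(C(F)(F)F)nn3C)n2)n1` gives only a limit, > 30000 nM.
Compound 3 `Cc1cncc(-c2noc([C@H](C)NC(=O)c3cc(C(F)(F)F)nn3C)n2)c1` gives 1370 nM.

Among the two real numbers, compound 3 has the highest; its nearest neighbour is compound 1, separated by a 10-fold higher number from compound 1 to compound 3 (1.00 log units; beyond the scatter). The change now followed, from compound 3 to compound 4 `Cc1ccnc(-c2noc([C@H](C)NC(=O)c3cc(C(F)(F)F)nn3C)n2)c1`, is 4-methylpyridin-2-yl in place of 5-methylpyridin-3-yl on an aromatic carbon. Among the measured compounds shown here, two measured steps bear on it. The step of an at least 220-fold higher number from compound 1 to compound 2 (2.34 log units; beyond the scatter) shows that a methyl-bearing pyridin-2-yl group in this position carried the result out to the limit (the limit of > 30000 nM in this assay, at which 1 of the 3 values shown sits). The step of an at least 21-fold lower number from compound 2 to compound 3 (1.34 log units; beyond the scatter) shows that the pyridin-3-yl form brings the number back into the measurable range. Compound 4 again carries a pyridin-2-yl group and differs from compound 2 only in where its methyl sits, so a rise beyond the scatter is expected in this assay, with a real chance that only a limit is reported. The expected step is an 8.8-fold higher number from compound 3 to compound 4 (0.94 log units; beyond the scatter). Compound 4 is therefore estimated at 12000 nM, within 3000 nM to 40000 nM.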

Compound 4, half-maximal inhibitory concentration: 4470 nM
Beside the measured number, compound 4's estimate is 2.7-fold (0.43 log units) above it; low and high end bracket the measured number.
By their numbers in this assay, from the lowest: compound 1; then compound 3; then compound 4. At a limit, above all of these: compound 2.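

In this assay, a pyridin-2-yl group does not by itself push the result to the limit: moving only the methyl gives a measurable number (an at least 6.7-fold lower number from compound 2 to compound 4 (0.82 log units; beyond the scatter)), so the methyl's place on the ring matters as well. Compound 2 remains a limit and not a number: (the limit of > 30000 nM in this assay, at which 1 of the 4 values shown sits). The pyridin-2-yl form of compound 4 still gives weaker inhibition than the pyridin-3-yl form (a 3.3-fold higher number from compound 3 to compound 4 (0.51 log units; beyond the scatter)), and the gap to the 3-fluorophenyl group stays large (a 33-fold higher number from compound 1 to compound 4 (1.52 log units; beyond the scatter)).

The compounds shown leave open how a pyridine ring with no methyl would read, and so how much of the distance from compound 1 belongs to the ring nitrogen and how much to the methyl. They also leave open how an amine or a methoxy group would read in the methyl's place.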